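The compounds below may be only part of what the source reports. "The series", "measured", "known", "first", "only" and "open" are said of these compounds alone.

Measured so far:
compound 1 `O=C(O)c1ccc(Cl)c(-c2cccc(COc3ccc4c(c3)CN(C3CCCC3)C4=O)c2)c1` gives 100%
compound 2 `O=C(O)c1cc(-c2cccc(COc3ccc4c(=O)n(C5CCCC5)sc4c3)c2)ccc1F` gives 100%
compound 3 `O=C(O)c1cc(-c2cccc(COc3ccc4c(=O)n(C5CC5)sc4c3)c2)ccc1Cl` gives 100%

In an ADME assay on a cell-free system (plasma, Rattus norvegicus) for metabolic stability, read by LC-MS, with a stated time of 1 h, at 37 degrees C, tested at 100 uM (on this read-out higher numbers stand for a more stable compound and lower numbers for a less stable compound), compound 1 reads 100% and stands level with compound 2 (100%) and compound 3 (100%). Nothing separates the three at the digits available.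

Compound 4 `O=C(O)c1ccc(-c2cccc(COc3ccc4c(c3)CN(C3CCCC3)C4=O)c2)c(Cl)c1` has the same atoms as compound 1, joined differently (4-carboxy-2-chlorophenyl in place of 5-carboxy-2-chlorophenyl on an aromatic carbon). The change sits on an aromatic carbon of a six-membered aromatic ring of carbon only, meta to a large group.

Among the measured compounds shown here, no pair of measured compounds differs in one place only, and no measured compound carries the 4-carboxy-2-chlorophenyl group, so this change has no direct test. With compound 1 at (100%) and the other two level with it, no step beyond the scatter is expected in this assay, and neither direction is favoured. The expected step (a number 2 percentage points lower from compound 1 to compound 4 (within the scatter)) is estimated to remain within the scatter. The estimated reading for compound 4 is (98%), with an expected range (88% to 100%).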

Compound 4, percent of the compound remaining: 100%
Compound 4: the middle estimate sits 2 percentage points below what was measured, and the stated range covers the measured number.
By their numbers in this assay, from the lowest: compounds 1, 2, 3 and 4 (each within the scatter of the next).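

In this assay, among the compounds shown here, 4-carboxy-2-chlorophenyl in place of 5-carboxy-2-chlorophenyl gives no change at the digits printed from compound 1 to compound 4 (within the scatter) and provides the first comparison that differs in one place only. At this position, on an aromatic carbon meta to a large group, this rearrangement of the same atoms leaves the read-out without a step beyond the scatter, so the read-out does not distinguish the two arrangements. No measured information on the compounds explains this result.

On these data alone, whether an amide or a tetrazole in place of the carboxylic acid, or a methoxy group in place of the chlorine, would change the reading remains open. As far as these compounds go, it is also open whether the same rearrangement would read alike on the core of compound 2.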